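This account rests on a few compounds, and the source may have more. Where it says the series, first, only, none or still open, it means among the compounds named here.

Compound 1 `Cn1cc(-c2nc3ccccc3n2C(=O)c2ccccc2Br)c2ccccc21` was tested in a functional assay on MCF7 cells (Homo sapiens) for inhibition, read by MTT assay, with a stated time of 24 h (a lower number here means a stronger inhibitor of growth, a higher number a weaker inhibitor of growth), where compound 1 gives 70100 nM. Compound 2 `Cn1cc(-c2nc3ccccc3n2C(=O)c2cccc(Br)c2)c2ccccc21` differs from it by 3-bromophenyl in place of 2-bromophenyl on a carbonyl carbon; in this assay compound 2 gives 63400 nM, a change of a 1.1-fold lower number from compound 1 to compound 2 (0.04 log units; within the scatter). Compound 3 `Cn1cc(-c2nc3ccccc3n2C(=O)c2ccccc2Br)c2cc(Br)ccc21` differs from compound 1 by bromo in place of hydrogen on an aromatic carbon, and in this assay compound 3 gives 73600 nM, a change of a 1.0-fold higher number from compound 1 to compound 3 (0.02 log units; within the scatter). All three numbers lie within the scatter of one another, so no order among compound 1, compound 2 and compound 3 can be read from them.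

Compound 4 `Cn1cc(-c2nc3ccccc3n2C(=O)c2cccc(Br)c2)c2cc(Br)ccc21` has not yet been measured in this assay. It differs from compound 3 by 3-bromophenyl in place of 2-bromophenyl on a carbonyl carbon, which is the same change as that from compound 1 to compound 2, now made on a core that differs from the core of compound 1 by bromo in place of hydrogen on an aromatic carbon. The surroundings of the changed carbonyl carbon are the same in both pairs. For compound 4 a step of about the same size is expected, a 1.1-fold lower number from compound 3 to compound 4 (0.05 log units; within the scatter), because the like change gave a 1.1-fold lower number from compound 1 to compound 2 (0.04 log units; within the scatter). In this assay compound 4 is therefore expected to give roughly 66000 nM, most likely between 35000 nM and 130000 nM, with the bromo on the core of compound 3 not expected to alter the outcome given that compound 3 and compound 1 sit within the scatter of each other.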

Compound 4, concentration for 50% growth inhibition: 68200 nM
For compound 4 the middle estimate is 1.0-fold (0.01 log units) below the measured one; low and high end bracket the measured number.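

The change from 2-bromophenyl to 3-bromophenyl on a carbonyl carbon carries over between the two cores in this assay, giving a 1.1-fold lower number from compound 3 to compound 4 (0.03 log units; within the scatter): the same change on two cores in this assay, a 1.1-fold lower number (0.04 log units; within the scatter) from compound 1 to compound 2 and a 1.1-fold lower number (0.03 log units; within the scatter) from compound 3 to compound 4, 1.0-fold (0.01 log units) apart, within the scatter of two such steps

Bromo in place of hydrogen on an aromatic carbon behaves in the same way, giving a 1.1-fold higher number from compound 2 to compound 4 (0.03 log units; within the scatter): the same change on two cores in this assay, a 1.0-fold higher number (0.02 log units; within the scatter) from compound 1 to compound 3 and a 1.1-fold higher number (0.03 log units; within the scatter) from compound 2 to compound 4, 1.0-fold (0.01 log units) apart, within the scatter of two such steps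

Within the data shown here, every one of these steps lies within the scatter, so the agreement shows only that neither change shifts the number measurably on either core; it does not show that a change with a real effect would carry over intact, and it gives no order among the four compounds.

The compounds shown leave open whether any group on the phenyl ring other than bromo, such as a methoxy group, an amine or a carboxylic acid, would move the number beyond the scatter, and whether such a step would then hold from one core to the other. They also leave open whether the two bromo changes stay as small in cells other than those used here.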